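This account rests on a few compounds, and the source may have more. Where it says the series, first, only, none or still open, it means among the compounds named here.

In a functional assay on SK-BR-3 cells (Homo sapiens) for antiproliferative activity (a higher number here means a weaker inhibitor, a lower number a stronger inhibitor), the measured compounds are:
- compound 1 `CCN(C)CCCOc1ccc2cc(NC(=O)c3ccc(O)c(CC=C(C)C)c3)c(=O)oc2c1C`: 730 nM
- compound 2 `CC(C)=CCc1cc(C(=O)Nc2cc3ccc(OCCCN(C)C4CCCCC4)c(C)c3oc2=O)ccc1O`: 970 nM

Within the data shown here, compound 2 sits within the scatter of compound 1, the only other compound measured. Compound 3 `CC(C)=CCc1cc(C(=O)Nc2cc3ccc(OCCCN[C@@H]4C[C@H]5CC[C@@H]4C5)c(C)c3oc2=O)ccc1O` differs from compound 2 by one change: a group of 8 heavy atoms (7 carbon, 1 nitrogen; 2 five-membered non-aromatic rings of carbon only) in place of a group of 8 heavy atoms (7 carbon, 1 nitrogen; one six-membered non-aromatic ring of carbon only), on a saturated chain carbon, three bonds along the chain from an oxygen on an aromatic ring. Among the measured compounds shown here, the only measured step bearing on this also alters the substituent on the amine nitrogen, a 1.3-fold higher number from compound 1 to compound 2 (0.12 log units; within the scatter), and it stays within the scatter. For the measured compounds named here, no measured compound carries the entering group, but no shift beyond the scatter is expected in this assay. The estimated change is a 1.1-fold lower number from compound 2 to compound 3 (0.06 log units; within the scatter). For compound 3 the estimated value is 850 nM, with an expected range of 350 nM to 2100 nM.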

Compound 3, half-maximal inhibitory concentration: 770 nM
Beside the measured number, compound 3's estimate is 1.1-fold (0.04 log units) above it; measured number inside the range.
By their numbers in this assay, from the lowest: compounds 1, 3 and 2 (each within the scatter of the next).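

In this assay, the group with 2 five-membered non-aromatic rings gives a 1.3-fold lower number from compound 2 to compound 3 (0.10 log units; within the scatter) and a 1.1-fold higher number from compound 1 to compound 3 (0.02 log units; within the scatter). This place on the saturated chain therefore takes a group with a hydrogen-bond donor, which cyclohexyl(methyl)amino lacks, with no step beyond the scatter. No evidence offers a reason for this result.

The ring change and the added donor arrive together in compound 3, so their separate contributions cannot be told apart. On these data alone, whether a morpholine, a carboxylic acid or a longer chain at this place would also stay within the scatter remains open.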